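The source may report more compounds than this note shows. Statements on the series, on what has been measured and on what is new or still open speak of the compounds shown alone.

Measured compounds in an assay on isolated protein for inhibition of 5-hydroxytryptamine receptor 4 (Homo sapiens); a higher number here means a weaker inhibitor, a lower number a stronger inhibitor:
compound 1 `CCN1CCN(S(=O)(=O)CCCN2CCC(CNC(=O)c3cccc4c3OCCO4)CC2)CC1` gives 0.0501 nM
compound 2 `CS(=O)(=O)N1CCN(S(=O)(=O)CCCN2CCC(CNC(=O)c3cccc4c3OCCO4)CC2)CC1` gives 0.316 nM
compound 3 `O=C(NCC1CCN(CCCS(=O)(=O)N2CCOCC2)CC1)c1cccc2c1OCCO2` gives 0.398 nM

Among these three numbers, compound 1 holds the lowest. Its nearest neighbour is compound 2, reached by a 6.3-fold higher number from compound 1 to compound 2 (0.80 log units; beyond the scatter), and the furthest is compound 3, reached by a 7.9-fold higher number from compound 1 to compound 3 (0.90 log units; beyond the scatter). Between compounds 2 and 3 the step is a 1.3-fold higher number from compound 2 to compound 3 (0.10 log units; within the scatter), so those two cannot be told apart.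

Compound 4 `CCCC1CCN(S(=O)(=O)CCCN2CCC(CNC(=O)c3cccc4c3OCCO4)CC2)CC1` has not yet been measured in this assay. It differs from compound 1 in one place: 4-propylpiperidin-1-yl in place of 4-ethylpiperazin-1-yl on a sulfonyl sulfur

Both measured steps that start from compound 1 also exchange the 4-ethylpiperazin-1-yl on the sulfonyl sulfur for another ring, and each cost a modest rise in the number, beyond the scatter. The change to compound 4 is of the same kind in the same place, so a modest rise of similar size is expected rather than no change, although a third ring need not behave like the first two. Compound 4 is therefore estimated at 0.3 nM, with a range from 0.08 nM to 1.2 nM, which would mean an expected step of a 6.0-fold higher number from compound 1 to compound 4 (0.78 log units; beyond the scatter).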

Compound 4, inhibition constant: 0.0631 nM
Beside the measured number, compound 4's estimate is 4.8-fold (0.68 log units) above it; the whole stated range lies above it.
By their numbers in this assay, from the lowest: compounds 1 and 4 (each within the scatter of the next); then compounds 2 and 3 (each within the scatter of the next).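

In this assay the step of a 1.3-fold higher number from compound 1 to compound 4 (0.10 log units; within the scatter) shows that exchanging the 4-ethylpiperazin-1-yl on the sulfonyl sulfur for another ring need not raise the number, so the rise seen with the earlier rings does not apply to every replacement. The new ring stands apart from the other two, with a 6.3-fold lower number from compound 3 to compound 4 (0.80 log units; beyond the scatter) on replacing morpholin-4-yl and a 5.0-fold lower number from compound 2 to compound 4 (0.70 log units; beyond the scatter) on replacing 4-(methylsulfonyl)piperazin-1-yl; these four compounds therefore fall into two pairs, and compound 4 stays in the lower pair with one ring nitrogen fewer than compound 1 and a propyl chain in place of ethyl. Nothing available explains why the rings divide in this way.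

Because the ring and its chain change together between compound 1 and compound 4, the compounds shown do not separate the contribution of each, and a 4-propylpiperazin-1-yl or a 4-ethylpiperidin-1-yl on the same sulfur would be needed to do so. They also leave open how much of the chain the lower pair requires, as an unsubstituted piperidin-1-yl or a 4-butylpiperidin-1-yl would show.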